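The source may report more compounds than this note shows. Statements on the series, on what has been measured and on what is new or still open speak of the compounds shown alone.

Measured compounds:
- Compound 1 `Nc1nc(N)c(CCCNc2cc(F)c(F)cc2[N+](=O)[O-])c(O)n1`: 97000 nM in a functional assay on CCRF-CEM cells (Homo sapiens) for cytotoxicity, in the absence of a further agent; on this read-out lower numbers stand for stronger inhibition and higher numbers for weaker inhibition
- Compound 2 `COC(=O)c1ccc(CN(CCCc2c(N)nc(N)nc2O)c2cc(F)c(F)cc2[N+](=O)[O-])cc1`: 59000 nM in this assay
- Compound 3 `Nc1nc(N)c(CCCN(Cc2ccc(NC(CCC(=O)O)C(=O)O)cc2)c2cc(F)ccc2[N+](=O)[O-])c(O)n1`: > 100000 nM in this assay, a limit of the assay rather than a number

Among the measured compounds shown here, compound 1 gives the highest of the two numbers; compound 2 lies nearest, and the only measured step, a 1.6-fold lower number from compound 1 to compound 2 (0.22 log units; within the scatter), stays within the scatter. Compound 3 sits at the limit of > 100000 nM in this assay, at which 1 of the 3 values shown sits.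

Compound 4 `Nc1nc(N)c(CCCNc2cc(F)c([N+](=O)[O-])cc2[N+](=O)[O-])c(O)n1` differs from compound 1 by nitro in place of fluoro on an aromatic carbon. For the measured compounds named here, no measured step touches this kind of change, and the one measured step was within the scatter, so no movement beyond the scatter is expected in this assay in either direction. For compound 4 the estimated step is a 1.2-fold lower number from compound 1 to compound 4 (0.08 log units; within the scatter). Compound 4 is therefore expected at 80000 nM, within 30000 nM to 200000 nM.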

Compound 4, half-maximal inhibitory concentration: 1000 nM
The estimate for compound 4 lay 80-fold (1.90 log units) above the measured number; measured number below the stated range.
By their numbers in this assay, from the lowest: compound 4; then compounds 2 and 1 (each within the scatter of the next). At a limit, above all of these: compound 3.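

In this assay nitro in place of fluoro on this aromatic carbon brings a 97-fold lower number from compound 1 to compound 4 (1.99 log units; beyond the scatter) and so gives the first step beyond the scatter among these compounds. Among the compounds shown here, this position, para to a large group, can therefore move the number strongly, whereas the one earlier step, made on the nitrogen, stayed within the scatter. Nothing measured here accounts for the size of this step. The compounds shown leave open whether an amine or a carboxylic acid on this same carbon would bring a similar step.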